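Aroyl replacing the amide hydrogen on a chloro-substituted triazene

The compounds below may be only part of what the source reports. "The series", "measured", "known", "first", "only" and "open" are said of these compounds alone.

Measured so far:
Compound 1 `CC(=O)N(/N=N/c1ccc([N+](=O)[O-])cc1Br)c1ccc([N+](=O)[O-])cc1Br` gives 550 nM in a functional assay on HeLa cells (Homo sapiens) for cytotoxicity, read by MTT assay, with a stated time of 72 h; a higher number here means a weaker inhibitor, a lower number a stronger inhibitor.
Compound 2 `O=C(c1ccccc1C(F)(F)F)N(/N=N/c1ccc([N+](=O)[O-])cc1Br)c1ccc([N+](=O)[O-])cc1Br` gives 13300 nM in this assay.
Compound 3 `O=[N+]([O-])c1ccc(/N=N/Nc2ccc([N+](=O)[O-])cc2Cl)c(Cl)c1` gives 3010 nM in this assay.

Compound 3 stands second highest of the three numbers; compound 2 lies above it and compound 1 below it, both beyond the scatter. Compound 4 `O=C(c1cccc(F)c1)N(/N=N/c1ccc([N+](=O)[O-])cc1Cl)c1ccc([N+](=O)[O-])cc1Cl` has not yet been measured. It differs from compound 3 in one place: (3-fluorophenyl)carbonyl in place of hydrogen on a nitrogen on an aromatic ring. Going by the values given here, no measured step shows a hydrogen on that nitrogen being exchanged for an acyl group, so the direction of that exchange cannot be read off directly. One step does bear on the kind of group entering: a 24-fold higher number from compound 1 to compound 2 (1.38 log units; beyond the scatter), which shows that an aroyl group on the triazene nitrogen gives a far weaker inhibitor than an acetyl group does. Compound 2, the closest measured aroyl compound, stands well above compound 3. On that basis compound 4 is expected to be a weaker inhibitor than compound 3, with a step of a 2.7-fold higher number from compound 3 to compound 4 (0.42 log units; beyond the scatter). The estimate for compound 4 in this assay is 8000 nM, expected to fall between 2500 nM and 25000 nM.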

Compound 4, half-maximal inhibitory concentration: 2500 nM
Beside the measured number, compound 4's estimate is 3.2-fold (0.51 log units) above it; the measured number falls inside the stated range.
By their numbers in this assay, from the lowest: compound 1; then compounds 4 and 3 (each within the scatter of the next); then compound 2.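

In this assay, the step is a 1.2-fold lower number from compound 3 to compound 4 (0.08 log units; within the scatter), so this exchange on the nitrogen leaves the number within the usual scatter, even though a hydrogen gives way to a (3-fluorophenyl)carbonyl group of 9 heavy atoms. Going by these compounds alone, the earlier compounds offered only a 24-fold higher number from compound 1 to compound 2 (1.38 log units; beyond the scatter), a change from one acyl group to another on the core of compound 1; the new step is the first to set an acyl group against hydrogen on this nitrogen, and it shows that an aroyl group there need not bring a large change in the number. No supporting data are available to explain why this exchange and the earlier one differ so much in size.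

The compounds shown leave open whether the same holds for other acyl groups on this nitrogen, such as acetyl on the core of compound 3, or a longer chain such as butanoyl. They also leave open what happens when the aromatic ring of the aroyl group carries an amine or a carboxylic acid in place of the fluorine.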